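A few compounds are considered here, and "the series" means these few. Any claim that something is new, unique, unknown or untested is made for them only; others in the source may bear on it.

Cytotoxicity for the series was read in a functional assay on MCF7 cells (Homo sapiens) for cytotoxicity, read by MTT assay, with a stated time of 24 h; on this read-out higher numbers stand for weaker inhibition and lower numbers for stronger inhibition. Measured so far:

compound 1 `COc1ccc(Nc2ncnc3cc(OC)c(OCCCSc4nc5ccccc5s4)cc23)cc1`: 14200 nM
compound 2 `COc1cc2ncnc(Nc3ccc(C)cc3)c2cc1OCCCSc1nc2ccccc2s1`: 14300 nM
compound 3 `COc1ccc(Nc2ncnc3cc(OC)c(OCCCSc4nc5ccccc5o4)cc23)cc1`: 13100 nM

The change from compound 1 to compound 2 is methyl in place of methoxy on an aromatic carbon, and it gave a 1.0-fold higher number from compound 1 to compound 2 (0.00 log units; within the scatter). The two cores differ by 1,3-benzoxazol-2-yl in place of 1,3-benzothiazol-2-yl on a sulfur, with a 1.1-fold lower number from compound 1 to compound 3 (0.04 log units; within the scatter). Compound 4 `COc1cc2ncnc(Nc3ccc(C)cc3)c2cc1OCCCSc1nc2ccccc2o1` is not yet measured; it differs from compound 3 by methyl in place of methoxy on an aromatic carbon, the same change as from compound 1 to compound 2, on the same place. Within the data shown here, all three numbers so far lie within the scatter of one another, so nothing in the data separates any compound from the others.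

For compound 4 in this assay the step of a 1.0-fold lower number from compound 3 to compound 4 (0.00 log units; within the scatter) is expected, resting on the flat step a 1.0-fold higher number from compound 1 to compound 2 (0.00 log units; within the scatter) seen for the same change. Compound 4 is therefore estimated at 13000 nM, likely between 7000 nM and 26000 nM.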

Compound 4, half-maximal inhibitory concentration: 12100 nM
Compound 4: middle estimate off by 1.1-fold (0.03 log units), on the high side; measured number inside the range.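

Methyl in place of methoxy gives a 1.1-fold lower number from compound 3 to compound 4 (0.03 log units; within the scatter), and it behaves alike on both cores in this assay: the same change on two cores in this assay, a 1.0-fold higher number (0.00 log units; within the scatter) from compound 1 to compound 2 and a 1.1-fold lower number (0.03 log units; within the scatter) from compound 3 to compound 4, 1.1-fold (0.04 log units) apart, within the scatter of two such steps. 1,3-Benzoxazol-2-yl in place of 1,3-benzothiazol-2-yl gives a 1.2-fold lower number from compound 2 to compound 4 (0.07 log units; within the scatter), and this step also agrees with its earlier counterpart: the same change on two cores in this assay, a 1.1-fold lower number (0.04 log units; within the scatter) from compound 1 to compound 3 and a 1.2-fold lower number (0.07 log units; within the scatter) from compound 2 to compound 4, 1.1-fold (0.04 log units) apart, within the scatter of two such steps. Among these compounds, both changes therefore carry across these two cores as steps within the scatter, but this shows only that neither moves the number here, not that a larger effect would transfer or that other cores would behave alike.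

As far as these compounds go, whether any change shifts the number beyond the scatter remains open. An amine or a carboxylic acid in place of methoxy or methyl, or a longer chain to the sulfur, would test this.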